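Methylating a ring nitrogen: does tolerance rise again?

The source may hold more compounds than are shown below. What is called first, only, known or untested is meant among the compounds shown, and "the series" means these compounds.

Of the compounds shown here, three have been tested so far in an ADME assay on cells (Homo sapiens) for cytotoxicity, read by polymerase chain reaction, with a stated time of 3 days; a lower number here means that less compound is tolerated, a higher number that more compound is tolerated. Compound 1 `CNc1ccc2nc(-c3c(Cl)nc(N)nc3N[C@@H]3C[C@H](CO)[C@@H](O)[C@H]3O)sc2c1` gives 6000 nM in this assay. Compound 2 `CN(C)c1ccc2nc(-c3c(Cl)nc(N)nc3N[C@@H]3C[C@H](CO)[C@@H](O)[C@H]3O)sc2c1` carries the change methyl in place of hydrogen on a nitrogen on an aromatic ring relative to compound 1. Compound 2 reaches only the limit of the assay, > 25000 nM, so the tolerated concentration is not known as a number. Across this pair the number moves an at least 4.1-fold higher number from compound 1 to compound 2 (0.61 log units; beyond the scatter), which rests on (the limit of > 25000 nM in this assay, at which 1 of the 3 values shown sits). Compound 3 `Cc1nc(N)nc(N[C@@H]2C[C@H](CO)[C@@H](O)[C@H]2O)c1-c1nc2ccccc2s1` gives 4000 nM in this assay, a value that sits within the scatter of the value of compound 1; how the two cores differ is not broken down here.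

Compound 4 `CNc1nc(C)c(-c2nc3ccccc3s2)c(N[C@@H]2C[C@H](CO)[C@@H](O)[C@H]2O)n1` has not yet been measured. It differs from compound 3 by methyl in place of hydrogen on a nitrogen on an aromatic ring. Within the data shown here, this is the same kind of change as the one from compound 1 to compound 2, but the surroundings differ: in compound 1 the nitrogen also carries a saturated chain carbon, so that methylamino becomes dimethylamino, whereas in compound 3 the nitrogen bears only the aromatic carbon, so that amino becomes methylamino. The step from compound 3 to compound 4 is expected to be a 2.3-fold higher number from compound 3 to compound 4 (0.35 log units; beyond the scatter), set beside the measured step and tempered by the different surroundings. Compound 4 is therefore estimated to give 9000 nM in this assay, within 3000 nM to 25000 nM.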

Compound 4, half-maximal cytotoxic concentration: > 25000 nM
Compound 4 gave a limit, no number; the forecaster's own chance of this, stated with the estimate: 20%; at least 2.7-fold (0.44 log units) between middle value and limit.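

Putting methyl in place of hydrogen on a nitrogen on an aromatic ring gives a second rise in this assay, this time as amino to methylamino: the step is an at least 6.2-fold higher number from compound 3 to compound 4 (0.79 log units; beyond the scatter). In these two pairs, the direction of the change therefore carries over from one core to the other, and the two steps compare as follows: the same change on two cores in this assay, an at least 4.1-fold higher number (0.61 log units; beyond the scatter) from compound 1 to compound 2 and an at least 6.2-fold higher number (0.79 log units; beyond the scatter) from compound 3 to compound 4; the limit leaves it open whether they differ What remains unknown is the true size of either step, and so whether the core alters the effect, since both steps end at a limit of the assay and not at a number: the limit of > 25000 nM in this assay, at which 2 of the 4 values shown sit.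

The compounds shown leave open where the tolerated concentrations of compound 2 and compound 4 actually lie, and whether the same rise would appear on further cores. They also leave open whether a larger group on this nitrogen, such as an ethyl group or a longer chain, would do the same as methyl.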